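Adding a Second Fluoro to the 3-Fluorophenyl Group

The source may hold more compounds than are shown below. What is called first, only, known or untested is meant among the compounds shown, and "the series" means these compounds.

Compound 1 `Nc1scc(CN2CCN(c3ccc(Cl)cc3Cl)CC2)c1C(=O)c1ccc(Cl)cc1`: -54%
Compound 2 `Nc1scc(CN2CCN(c3ccc(F)cc3Cl)CC2)c1C(=O)c1ccc(Cl)cc1`: -39%
Compound 3 `Nc1scc(CN2CCN(c3cccc(F)c3)CC2)c1C(=O)c1ccc(Cl)cc1`: -86%

In a functional assay on CHO cells with adenosine receptor A1 (Homo sapiens) as the target, read by cAMP accumulation and immunoassay, with a stated time of 6 min, tested at 1 uM (a lower number here means a stronger effect, a higher number a weaker effect of the compound at the concentration tested), compound 3 gives -86%, the lowest of the three numbers shown. The step of a number 32 percentage points lower from compound 1 to compound 3 (beyond the scatter) and the step of a number 47 percentage points lower from compound 2 to compound 3 (beyond the scatter) both exchange the whole substituted phenyl group on the amine nitrogen in the ring, and both are large. For the measured compounds named here, the one step that changes only a single halogen, a number 15 percentage points higher from compound 1 to compound 2 (beyond the scatter), is modest.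

Compound 4 `Nc1scc(CN2CCN(c3cccc(F)c3F)CC2)c1C(=O)c1ccc(Cl)cc1` differs from compound 3 by fluoro in place of hydrogen on an aromatic carbon, placed ortho to the fluoro group already present. Going by the values given here, no measured pair adds a fluoro where a hydrogen stood, so the modest single-halogen step between compound 1 and compound 2 is the closest guide, and the large steps involved much bigger changes. A small step is therefore expected in this assay, of a size that may not rise beyond the scatter, with no firm direction. For compound 4 the estimate is -75%, with a range from -95% to -50%, expected to correspond to the step of a number 11 percentage points higher from compound 3 to compound 4 (beyond the scatter).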

Compound 4, a percentage reported as activity, at one concentration (the size of the read-out at that concentration, not a potency): -66%
For compound 4 the middle estimate is 9 percentage points below the measured one, and the stated range covers the measured number.
By their numbers in this assay, from the lowest: compound 3; then compound 4; then compound 1; then compound 2.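

In this assay, for the compounds shown here, this is the first measured case of a fluoro taking the place of a hydrogen, and on the 3-fluorophenyl group, ortho to the fluoro group, it gives a number 20 percentage points higher from compound 3 to compound 4 (beyond the scatter): one added atom at this position is enough to move the number beyond the scatter. The 2,3-difluorophenyl group still reads lower than both chloro-bearing groups, with a number 27 percentage points lower from compound 2 to compound 4 (beyond the scatter) and a number 12 percentage points lower from compound 1 to compound 4 (beyond the scatter), so compound 4 sits between compound 3 and those two compounds. Nothing available explains the size of the step from the added fluoro.

As far as these compounds go, whether a fluoro at other places on the same aromatic ring would move the number the same way remains open. So does how a methoxy, a nitrile or an amine would read at this position.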